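The compounds below may be only part of what the source reports. "The series", "measured", "known", "first", "only" and "open" are said of these compounds alone.

Compounds measured in an ADME assay on Vero cells (Chlorocebus sabaeus) for cytotoxicity, read by MTT assay, with a stated time of 72 h; on this read-out lower numbers stand for stronger inhibition and higher numbers for weaker inhibition:

- compound 1, `Cn1cc([N+](=O)[O-])cc1-c1nnc(C2CCCNC2)o1`, gives 611000 nM
- compound 2, `O=[N+]([O-])c1c[nH]c(-c2nnc(-c3cccs3)o2)c1`, gives 418000 nM
- compound 3, `Cn1cc([N+](=O)[O-])cc1-c1nnc(-c2cc(-c3ccccc3)nc3ccc(Cl)cc23)o1`, gives 328000 nM

All three numbers are high, meaning weak inhibition of cell growth, and compound 3 sits within the usual scatter of both compound 2 and compound 1, so the three cannot be told apart on this read-out. Compound 4, `O=[N+]([O-])c1c[nH]c(-c2nnc(-c3cc(-c4ccccc4)nc4ccc(Cl)cc34)o2)c1`, has not yet been tested. It differs from compound 3 only by hydrogen in place of methyl on an aromatic nitrogen. Within the data shown here, no measured pair shows this change on its own, so there is no directly comparable step to lean on. Among the measured compounds shown here, with every number so far of similar size, compound 4 is expected to stay in the same region, with a step of a 1.1-fold higher number from compound 3 to compound 4 (0.04 log units; within the scatter) that does not go beyond the scatter. The estimate for compound 4 in this assay is 360000 nM, between 150000 nM and 850000 nM.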

Compound 4, half-maximal inhibitory concentration: 281000 nM
Compound 4: middle estimate off by 1.3-fold (0.11 log units), on the high side; measured number inside the range.
By their numbers in this assay, from the lowest: compounds 4, 3, 2 and 1 (each within the scatter of the next, the first and the last beyond it).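

Among these compounds, compound 3 and compound 4 form the first pair that isolates this one change, hydrogen in place of methyl on an aromatic nitrogen. In this assay, the change gives a 1.2-fold lower number from compound 3 to compound 4 (0.07 log units; within the scatter), so removing the methyl leaves the cytotoxicity reading indistinguishable for this pair. No measurement here accounts for this result.

The compounds shown leave open whether the same change would read alike with a different group on the other side of the core. They also leave open whether a longer chain such as ethyl, or a chain carrying an amine, on the same aromatic nitrogen would move the number beyond the scatter.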